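The source may report more compounds than this note shows. Statements on the series, on what has been measured and on what is new or still open speak of the compounds shown alone.

Compound 1 `C#CC(C)OC(=O)c1ccc(C(CC)(CC)c2ccc(OCCC(O)(CC)CC)c(C)c2)n1CC` is tested in a functional assay on Caco-2 cells (Homo sapiens) for antiproliferative activity, read by MTT assay, with a stated time of 48 h; a higher number here means a weaker inhibitor, a lower number a stronger inhibitor. In this assay compound 1 gives > 50000 nM, which is a limit of the assay rather than a number. Compound 2 `CCC(C)C(NC(=O)c1ccc(C(CC)(CC)c2ccc(OCCC(O)(CC)CC)c(C)c2)n1CC)C(=O)OC` is changed on a carbonyl carbon. In this assay compound 2 gives > 50000 nM, again a limit. The step that the two limits leave unreadable from compound 1 to compound 2 cannot be sized because of the limit of > 50000 nM in this assay, at which 2 of the 2 values shown sit. Compound 3 `CCn1c(C(=O)N(C)CCO)ccc1C(CC)(CC)c1ccc(OCCC(O)(CC)CC)c(C)c1` carries (2-hydroxyethyl)(methyl)amino in place of (1-methylprop-2-yn-1-yl)oxy on a carbonyl carbon. Among the measured compounds shown here, the one measured step at that carbonyl carbon, a step that the two limits leave unreadable from compound 1 to compound 2, bears on this change, yet it offers no readable size and no direction. For the measured compounds named here, nothing among the measured compounds points to a number for compound 3 in this assay. Compound 3 is expected to give 80000 nM, with a range from 20000 nM to 300000 nM. The expected step that the limit leaves unreadable from compound 1 to compound 3 is estimated as none beyond the scatter, with a limit the most likely outcome.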

Compound 3, half-maximal inhibitory concentration: 74 nM
The estimate for compound 3 lay 1100-fold (3.03 log units) above the measured number, outside the stated range (below it).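

The carbonyl carbon proves to be a place where the group decides the outcome, which the two limits alone could not show: with (2-hydroxyethyl)(methyl)amino in place of (1-methylprop-2-yn-1-yl)oxy, this assay shows an at least 670-fold lower number from compound 1 to compound 3 (2.82 log units; beyond the scatter), and the other comparison gives an at least 670-fold lower number from compound 2 to compound 3 (2.82 log units; beyond the scatter). A nitrogen on that carbonyl carbon is not enough in itself, as compound 2 also carries one and remains at a limit of the assay. Both steps are minimum sizes only, because the true values of compound 1 and compound 2 lie beyond what the assay reports: the limit of > 50000 nM in this assay, at which 2 of the 3 values shown sit.

The compounds shown leave open whether the activity of compound 3 depends on the hydroxyl of its side chain or on the methyl on its nitrogen. They also leave open how a 3-hydroxypropyl chain, a dimethylamino group or a carboxylic acid at the end of the chain would fare on the same carbonyl carbon.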